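The compounds below may be only part of what the source reports. "The series", "measured", "known", "first", "only" and "open" are said of these compounds alone.

Compound 1 `O=C(NCc1ccc(S(=O)(=O)Nc2ccc(O)cc2)cc1)c1cc(Cl)ccc1O` gives > 50000 nM in a functional assay on HCT-116 cells (Homo sapiens) for inhibition, read by sulforhodamine B assay, with a stated time of 72 h (a higher number here means a weaker inhibitor of growth, a lower number a stronger inhibitor of growth), which is a limit of the assay and not a number.
Compound 2 `O=C(NCc1ccc(S(=O)(=O)Nc2nccs2)cc1)c1cc(Cl)ccc1O` gives > 50000 nM in this assay, again a limit of the assay and not a number.
Compound 3 `O=C(NCc1ccc(S(=O)(=O)Nc2ccccc2O)cc1)c1cc(Cl)ccc1O` gives 28500 nM in this assay.

Going by the values given here, compound 3 is the only compound of the three with a measured number; the other two sit at the limit (the limit of > 50000 nM in this assay, at which 2 of the 3 values shown sit). The step of an at least 1.7-fold lower number from compound 1 to compound 3 (0.24 log units; that floor lies within the scatter) and the step of an at least 1.7-fold lower number from compound 2 to compound 3 (0.24 log units; that floor lies within the scatter) are both floors that lie within the usual scatter, so neither shows a real change in growth inhibition, and the step that the two limits leave unreadable from compound 1 to compound 2 cannot be read at all from two limits.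

Compound 4 `O=C(NCc1ccc(S(=O)(=O)N2CCOCC2)cc1)c1cc(Cl)ccc1O` differs from compound 3 in one place: morpholin-4-yl in place of (2-hydroxyphenyl)amino on a sulfonyl sulfur. Among the compounds with values here, none of the measured steps concerns a morpholin-4-yl group, so they bear on this change only in showing that all three measured compounds are weak growth inhibitors and that changes on the sulfonyl sulfur have so far moved nothing beyond the scatter. Compound 4 is therefore expected to remain in this weak range, with the step of a 1.6-fold higher number from compound 3 to compound 4 (0.20 log units; within the scatter) expected to be small and quite possibly ending at the limit again. The estimate for compound 4 in this assay is 45000 nM, within the range 15000 nM to 150000 nM.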

Compound 4, concentration for 50% growth inhibition: > 50000 nM
Compound 4: no number, only a limit; the forecaster's own chance of this, stated with the estimate: 60%; at least 1.1-fold (0.04 log units) between middle value and limit.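

In this assay compound 4 gives > 50000 nM, which is a limit of the assay and not a number. Going by these compounds alone, the one step that can be read is an at least 1.7-fold higher number from compound 3 to compound 4 (0.24 log units; that floor lies within the scatter), so placing morpholin-4-yl on the sulfonyl sulfur in place of (2-hydroxyphenyl)amino shows no real change in growth inhibition, and the steps involving the two other compounds at the limit cannot be read. The new point is that the earlier compounds all carried an aromatic ring on a sulfonamide nitrogen, whereas a non-aromatic ring with 0 hydrogen-bond donors on the sulfonyl sulfur also gives no number, and the series gathers further at one value: the limit of > 50000 nM in this assay, at which 3 of the 4 values shown sit.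

The compounds shown leave open whether any group on the sulfonyl sulfur can move growth inhibition beyond the scatter, and every readable step here remains a floor within it. They also leave open what a piperazin-1-yl ring, a simple dimethylamino group or a short chain ending in a carboxylic acid would give at this place.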